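This account rests on a few compounds, and the source may have more. Where it says the series, first, only, none or still open, it means among the compounds named here.

Working notes on the series, read in an assay on isolated protein for agonist activity at Bile acid receptor (Homo sapiens), read by TR-FRET, with a stated time of 3 h, in the absence of a further agent; a higher number here means that more compound is needed for the effect, a lower number that less compound is needed. Compound 1 `CCOc1cccc(C(=O)Nc2cccc(C(=O)O)c2)c1` gives 2350 nM in this assay. Compound 2 `O=C(O)c1cccc(NC(=O)c2cccc(OCc3ccccc3)c2)c1` gives 1160 nM in this assay. Among the measured compounds shown here, the one measured step, a 2.0-fold lower number from compound 1 to compound 2 (0.31 log units; beyond the scatter), is the only comparison so far. Compound 2 thus stands at the lowest of the two numbers in hand, with compound 1 the nearest and higher.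

Compound 3 `Cc1ccc(COc2cccc(C(=O)Nc3cccc(C(=O)O)c3)c2)cc1` has not yet been measured in this assay. It differs from compound 2 by methyl in place of hydrogen on an aromatic carbon. For the measured compounds named here, no measured step carries this exact change. Going by the values given here, the only step available, a 2.0-fold lower number from compound 1 to compound 2 (0.31 log units; beyond the scatter), enlarged the same end of the molecule from methyl to phenyl and gave a modest gain that was beyond the scatter. A single methyl placed onto that phenyl is a much smaller change than the one already made there, so the expectation is for little or no movement in this assay beyond the scatter, with a slight lean toward a lower number. Compound 3 is therefore estimated at 900 nM in this assay, within 400 nM to 2000 nM. The expected step of a 1.3-fold lower number from compound 2 to compound 3 (0.11 log units; within the scatter) is accordingly small.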

Compound 3, half-maximal effective concentration: 1430 nM
For compound 3 the middle estimate is 1.6-fold (0.20 log units) below the measured one; low and high end bracket the measured number.
By their numbers in this assay, from the lowest: compounds 2, 3 and 1 (each within the scatter of the next, the first and the last beyond it).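

Among the compounds shown here, the methyl at this place, para to a large group, gives a 1.2-fold higher number from compound 2 to compound 3 (0.09 log units; within the scatter) in this assay, so the change from benzyl to 4-methylbenzyl produces no step that can be read beyond the scatter, and this is the first reading of a substituent on the outer phenyl rather than of the phenyl itself. Measured against the shared starting point, the picture also narrows: a 1.6-fold lower number from compound 1 to compound 3 (0.22 log units; within the scatter) stays within the scatter, whereas a 2.0-fold lower number from compound 1 to compound 2 (0.31 log units; beyond the scatter) lies just beyond it, so the modest step seen with the unsubstituted phenyl does not carry over as a step beyond the scatter once the methyl is present, and the small size of all these steps limits what can be read from them. No measurement bears on why this methyl leaves the number in this range.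

A single small group at a single place says little about the outer ring as a whole. From the compounds shown here alone, whether an amine, a methoxy group or a chlorine at this place, or a longer chain in place of the methyl, would give a step beyond the scatter remains open.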